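Swapping Methyls for Bromines on a Low-Toxicity Scaffold

The source may hold more compounds than are shown below. What is called first, only, known or untested is meant among the compounds shown, and "the series" means these compounds.

Compound 3 `Cc1cc(C)cc(C(=O)c2cc(Cl)ccc2OCCn2ccc(=O)[nH]c2=O)c1` was tested in an ADME assay on MT4 cells (Homo sapiens) for cytotoxicity, read by MTT assay, with a stated time of 4 days; on this read-out lower numbers stand for higher toxicity in this test and higher numbers for lower toxicity in this test. In this assay compound 3 gives > 313000 nM, which is a limit of the assay rather than a measured number. Two close relatives share this outcome. Compound 1 `O=C(c1ccccc1)c1cc(Cl)ccc1OCCn1ccc(=O)[nH]c1=O` gives > 337000 nM in this assay, again a limit. Compound 2 `Cc1cc(C)cc(C(=O)c2cc(Cl)ccc2OCCn2c(C)cc(=O)[nH]c2=O)c1` gives > 303000 nM in this assay, also a limit. All three readings thus sit at the edge of what the assay can report: the limit of > 337000 nM in this assay, at which 1 of the 3 values shown sits, the limit of > 303000 nM in this assay, at which 1 of the 3 values shown sits, and (the limit of > 313000 nM in this assay, at which 1 of the 3 values shown sits). As a result the step that the two limits leave unreadable from compound 1 to compound 3 has no readable size, and the same holds for a step that the two limits leave unreadable from compound 2 to compound 3.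

Compound 4 `O=C(c1cc(Br)cc(Br)c1)c1cc(Cl)ccc1OCCn1ccc(=O)[nH]c1=O` differs from compound 3 by 3,5-dibromophenyl in place of 3,5-dimethylphenyl on a carbonyl carbon. Neither measured step can guide the size of this change, since each one ends at a limit. Within the data shown here, with every value so far at a limit and no step showing a reading within reach, compound 4 is expected to behave in the same way, so the step of an at least 1.0-fold lower number from compound 3 to compound 4 (0.01 log units; that floor lies within the scatter) is estimated to stay within the scatter. Compound 4 is therefore estimated at 300000 nM in this assay, between 100000 nM and 400000 nM, most probably reported once more as a limit.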

Compound 4, half-maximal cytotoxic concentration: > 236000 nM
Compound 4: only a limit was reported; the forecaster's own chance of this, stated with the estimate: 80%; the middle value is on the limit's open side.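

In this assay compound 4 gives > 236000 nM, which is again a limit. The steps to compound 4 from compound 3 and from compound 1 therefore cannot be read. The compounds shown leave open at what concentration any of them would turn toxic to these cells, and whether the 3,5-dibromophenyl group changes that concentration at all.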